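The compounds below may be only part of what the source reports. "The series", "measured", "known", "first", "only" and "open" are said of these compounds alone.

Three analogues on a shared core, seen in the structure of compound 1 `NC1=NC2(CCOCC2)N(OCCCOc2cccc(Cl)c2)C(N)=N1`, differ only in the chlorine pattern of the phenyl ring that hangs from the oxygen on the saturated carbon. In an assay on isolated protein for inhibition of Dihydrofolate reductase (Homo sapiens), read by spectrophotometry, using NADPH, with stated times of 5 s and 6 min, tested at 5 uM (a higher number here means a stronger effect of the compound at the concentration tested, a lower number a weaker effect), compound 1 gives 83.2%. Compound 2 `NC1=NC2(CCOCC2)N(OCCCOc2ccc(Cl)c(Cl)c2)C(N)=N1` reaches a value that is a limit of this assay, > 90%. Compound 3 `NC1=NC2(CCOCC2)N(OCCCOc2ccc(Cl)cc2)C(N)=N1` likewise sits at a limit of this assay, > 90%. The step is a number at least 6.8 percentage points higher from compound 1 to compound 2 (that floor lies within the scatter), and in the same way a number at least 6.8 percentage points higher from compound 1 to compound 3 (that floor lies within the scatter); between the two dichloro and monochloro limits the step is a step that the two limits leave unreadable from compound 2 to compound 3. The common feature is the limit of > 90% in this assay, at which 2 of the 3 values shown sit, so compound 3 stands at the top of what this assay can report, together with compound 2, while compound 1 lies somewhat lower.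

Compound 4 `NC1=NC2(CCOCC2)N(OCCCOc2cccc(Cl)c2Cl)C(N)=N1` carries the change (2,3-dichlorophenyl in place of 4-chlorophenyl on an oxygen on a saturated carbon). Both measured steps that move a chlorine around this ring, from compound 1, end at the limit, and neither is readable in size. Nothing in the numbers distinguishes one chlorine arrangement from another beyond the scatter, so compound 4 is expected to remain near the limit, with a step of a number at least 2 percentage points lower from compound 3 to compound 4 (that floor lies within the scatter). The estimate for compound 4 in this assay is 88%, ranging from 72% to 96%.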

Compound 4, a percentage reported as inhibition, at one concentration (the size of the read-out at that concentration, not a potency): 81.7%
The estimate for compound 4 lay 6.3 percentage points above the measured number, within the range that was stated.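

In this assay, for the compounds shown here, compound 4 gives the first number that is not a limit for a ring carrying two chlorines, so a second chlorine on this ring does not by itself bring a compound to the limit. The chloro in place of hydrogen on an aromatic carbon (a number 1.5 percentage points lower from compound 1 to compound 4 (within the scatter)) makes no difference that these numbers can show, even though 2,3-dichlorophenyl now stands on the oxygen on a saturated carbon. Set against the two compounds at the limit, the change reads as two steps (a number at least 8.3 percentage points lower from compound 3 to compound 4 (that floor lies within the scatter); a number at least 8.3 percentage points lower from compound 2 to compound 4 (that floor lies within the scatter)), and their full size cannot be read because only floors are available: the limit of > 90% in this assay, at which 2 of the 4 values shown sit.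

The compounds shown therefore leave open whether the arrangement of chlorine on this ring matters at all, since no step here is printed as beyond the scatter. They also leave open what an amine or a carboxylic acid on this ring would do in place of chlorine, and what a longer chain would do in place of the saturated chain that carries the oxygen.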